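A few compounds are considered here, and "the series" means these few. Any claim that something is new, unique, unknown or untested is made for them only; others in the source may bear on it.

Of the compounds shown here, three have so far been measured in a physicochemical assay for solubility, at pH 7.4; a higher number here means a more soluble compound, a lower number a less soluble compound. Compound 1 `COc1ccc(NC(=O)Nc2cc(C)nc3ccccc23)cc1F` gives 2700 nM in this assay. Compound 2 `Cc1cc(NC(=O)Nc2ccccc2OC(F)(F)F)c2ccccc2n1` gives 4600 nM, the highest of the three numbers, though compound 1 lies within the usual scatter of it, so no order between those two can be claimed. Compound 3 `Cc1cc(NC(=O)Nc2ccc(OC(F)(F)F)cc2)c2ccccc2n1` gives 300 nM, a number that stands beyond the scatter below compound 2. Within the data shown here, no two of the measured compounds differ in one place only, so no single structural step is known from these data.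

Compound 4 `COc1ccccc1NC(=O)Nc1cc(C)nc2ccccc12` has not yet been measured in this assay. It differs from compound 2 by methyl in place of trifluoromethyl on an oxygen on an aromatic ring. Among the measured compounds shown here, with no measured step of this kind to lean on, the change from compound 2 to compound 4 is expected to give a step that stays within the scatter, or at most a modest rise. The account therefore expects compound 4 to reach 5000 nM, within a range from 1500 nM to 16000 nM, which means an expected step of a 1.1-fold higher number from compound 2 to compound 4 (0.04 log units; within the scatter).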

Compound 4, solubility: 100 nM
The estimate for compound 4 lay 50-fold (1.70 log units) above the measured number; the measured number lies below the stated range.
By their numbers in this assay, from the lowest: compound 4; then compound 3; then compounds 1 and 2 (each within the scatter of the next).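

Methyl in place of trifluoromethyl on an oxygen on an aromatic ring gives a 46-fold lower number from compound 2 to compound 4 (1.66 log units; beyond the scatter), the first step in this assay that can be read at a single place. It shows that this place is not indifferent to the change: with the rest of the structure the same, the exchange of this one group goes with a difference beyond the scatter, and methyl, with one heavy atom against four for trifluoromethyl, stands at the lower number. Nothing measured here accounts for the size of this step.

On these data alone, since one pair carries this result, it remains open whether trifluoromethoxy to methoxy would give a step of like size at another place or on another core. As far as these compounds go, it also remains open what a difluoromethyl or an ethyl group on this oxygen would give.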